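Nitro in place of hydrogen on a weakly active anilide

The source may hold more compounds than are shown below. What is called first, only, known or untested is meant among the compounds shown, and "the series" means these compounds.

Measured compounds in a functional assay on EC9706 cells (Homo sapiens) for cytotoxicity, read by MTT assay, with a stated time of 72 h; on this read-out lower numbers stand for stronger inhibition and higher numbers for weaker inhibition:
compound 1, `O=C(CSC(=S)N[C@H]1CCOC1=O)Nc1ccc(Cl)cc1`, > 128000 nM
compound 2, `O=C(CSC(=S)N[C@H]1CCOC1=O)Nc1ccc(Br)cc1`, 67400 nM
compound 3, `O=C(CSC(=S)N[C@H]1CCOC1=O)Nc1ccccc1`, > 128000 nM

Compound 3 carries the unsubstituted aryl ring of this series. Its value in this assay is a limit and not a number, so only a floor is known for it. The same holds for compound 1, as the limit of > 128000 nM in this assay, at which 2 of the 3 values shown sit, makes clear. Compound 2 is the only one of the three with a read number.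

The measured steps are small. From compound 1 to compound 2 there is an at least 1.8-fold lower number from compound 1 to compound 2 (0.27 log units; that floor lies within the scatter), and from compound 2 to compound 3 there is an at least 1.8-fold higher number from compound 2 to compound 3 (0.27 log units; that floor lies within the scatter); the step from compound 1 to compound 3 is a step that the two limits leave unreadable from compound 1 to compound 3, the two limits leaving it unreadable.

Compound 4, `O=C(CSC(=S)N[C@H]1CCOC1=O)Nc1cccc([N+](=O)[O-])c1`, differs from compound 3 by nitro in place of hydrogen on an aromatic carbon. Within the data shown here, no measured step concerns a nitro group, so the halogen steps give only an indirect guide: substitution on this ring has so far moved the value at most a little, and two of the three values rest at the limit. Compound 4 is therefore expected to stay weak, with an estimated step of an at least 1.2-fold lower number from compound 3 to compound 4 (0.10 log units; that floor lies within the scatter) in this assay. The estimate for compound 4 is 100000 nM, in a range from 35000 nM to 250000 nM, with a good chance that this assay again reports only a limit.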

Compound 4, half-maximal inhibitory concentration: > 128000 nM
Compound 4 ended at the assay's limit (the forecaster's own chance of this, stated with the estimate: 55%); middle value at least 1.2-fold (0.10 log units) from the limit.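

In this assay, among these compounds, compound 4 joins compound 1 and compound 3 at a limit and not a number, and no step from compound 3 to compound 4 can be read: the limit of > 128000 nM in this assay, at which 3 of the 4 values shown sit. The compounds shown leave open whether nitro in place of hydrogen on an aromatic carbon changes the value at all.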